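Pyridin-4-yl Replacing 3,5-Dimethoxyphenyl on an Isatin-Type Core

The source may hold more compounds than are shown below. What is called first, only, known or untested is meant among the compounds shown, and "the series" means these compounds.

Compound 2 `COc1ccc(CN2C(=O)C(=O)c3cc(-c4cc(OC)cc(OC)c4)ccc32)cc1` stands highest of the two numbers recorded here: in a functional assay on K562 cells (Homo sapiens) for antiproliferative activity, read by MTT assay, with a stated time of 48 h (a higher number here means a weaker inhibitor, a lower number a stronger inhibitor), compound 2 gives 510 nM, while compound 1 `COc1ccc(-c2ccc3c(c2)C(=O)C(=O)N3Cc2cc(C)cc(C)c2)cc1` gives 140 nM in this assay, a gap beyond the scatter. Compound 3 `COc1ccc(CN2C(=O)C(=O)c3cc(-c4ccncc4)ccc32)cc1` carries a change at the same place on the shared core of compound 2: pyridin-4-yl in place of 3,5-dimethoxyphenyl on an aromatic carbon. Among the compounds with values here, no measured pair shows the size of such a step. In this assay the step of a 1.1-fold lower number from compound 2 to compound 3 (0.05 log units; within the scatter) is expected to be small, within the scatter or at most a modest shift in either direction. Compound 3 is estimated to give 450 nM in this assay, with a range from 130 nM to 1600 nM.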

Compound 3, half-maximal inhibitory concentration: 40 nM
For compound 3 the middle estimate is 11-fold (1.05 log units) above the measured one; the whole stated range lies above it.
By their numbers in this assay, from the lowest: compound 3; then compound 1; then compound 2.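

In this assay, the group on this aromatic carbon turns out to matter greatly: pyridin-4-yl in place of 3,5-dimethoxyphenyl gives a 13-fold lower number from compound 2 to compound 3 (1.11 log units; beyond the scatter). Within the data shown here, this is the first measured pair at this position, and it shows that a single change here can produce a large step. Nothing measured explains the step.

The compounds shown leave open whether the step follows from the ring nitrogen entering or the two methoxy groups leaving. A plain phenyl or a pyridin-3-yl on this carbon would help separate those two changes.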